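From trifluoromethyl to phenoxy on a shared core

A few compounds are considered here, and "the series" means these few. Any claim that something is new, unique, unknown or untested is made for them only; others in the source may bear on it.

Compound 1 `Clc1ccccc1C1=NC(c2ccccc2)CO1` gives 3.56
Compound 2 `FC(F)(F)c1ccccc1C1=NC(c2ccccc2)CO1` gives 3.71

Both numbers come from a physicochemical assay for lipophilicity (a higher number here means a more lipophilic compound, a lower number a more polar compound), and cannot be told apart, so compound 2 stands level with compound 1 on this measure. Among the compounds with values here, the only measured step is a number 0.15 log units higher from compound 1 to compound 2 (within the scatter) and consists of trifluoromethyl in place of chloro on an aromatic carbon.

Compound 3 `c1ccc(Oc2ccccc2C2=NC(c3ccccc3)CO2)cc1` carries phenoxy in place of trifluoromethyl on an aromatic carbon, ortho to a large group. The change is counted as phenoxy in place of trifluoromethyl on an aromatic carbon and brings in a larger group with a ring of its own. The measured step involves neither phenoxy nor an added ring, so it offers only a weak guide, and the estimate rests mainly on the structural change. An upward move beyond the scatter is expected, estimated as a number 0.69 log units higher from compound 2 to compound 3 (beyond the scatter) in this assay as the read-out. Compound 3 is expected at 4.4 with an estimated range from 3.9 to 4.9 on this scale.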

Compound 3, partition coefficient: 5.61
The estimate for compound 3 lay 1.21 log units below the measured number; the whole stated range lies below it.
By their numbers in this assay, from the lowest: compounds 1 and 2 (each within the scatter of the next); then compound 3.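

In this assay, this position turns out to be able to shift the number a long way: phenoxy gives a number 1.90 log units higher from compound 2 to compound 3 (beyond the scatter) and, against chloro, a number 2.05 log units higher from compound 1 to compound 3 (beyond the scatter), whereas chloro and trifluoromethyl could not be told apart. The two earlier groups therefore sit together, while phenoxy, which enters with a six-membered aromatic ring of carbon only and an oxygen, sets compound 3 clearly apart from both. No measurement in hand explains why the step is so large.

From the compounds shown here alone, whether the added ring or the oxygen that joins it matters more stays open, and a methoxy group or a benzyl group in this place would help separate the two. Also open, going by these compounds, is how this assay would read with an amine or a carboxylic acid here.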